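The source may hold more compounds than are shown below. What is called first, only, known or untested is meant among the compounds shown, and "the series" means these compounds.

Three compounds that share one core, with its two fused rings and an amide on one of them, have been tested in a functional assay on the whole organism with Mus musculus as the target, with a stated time of 4 h; a higher number here means that more compound is needed for the effect, a lower number that less compound is needed. Compound 1 `COc1ccc2nc(NC(=O)CCC(=O)c3ccccc3)sc2c1` carries a methoxy group on the core, and in this assay compound 1 gives 100 mg/kg. Compound 2 `CC(=O)c1ccc2nc(NC(=O)CCC(=O)c3ccccc3)sc2c1` differs from compound 1 by a single change, (acetyl in place of methoxy on an aromatic carbon). In this assay compound 2 gives 300 mg/kg, so the change brought a 3.0-fold higher number from compound 1 to compound 2 (0.48 log units; beyond the scatter), a step beyond the usual scatter. Compound 3 `COc1ccc2nc(NC(=O)c3ccccc3C(=O)c3ccccc3)sc2c1` keeps the methoxy group but carries a different acid part on the amide; the difference between the core of compound 1 and that of compound 3 is not broken down here. In this assay compound 3 gives 300 mg/kg, level with compound 2 within the scatter and the highest of the three numbers together with it.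

Compound 4 `CC(=O)c1ccc2nc(NC(=O)c3ccccc3C(=O)c3ccccc3)sc2c1` has not yet been measured in this assay. For the measured compounds named here, it differs from compound 3 by acetyl in place of methoxy on an aromatic carbon, the same change as the one from compound 1 to compound 2, made at the same place on the core. Because the earlier step was a 3.0-fold higher number from compound 1 to compound 2 (0.48 log units; beyond the scatter), the same direction is expected here. The expected step from compound 3 to compound 4 is estimated as a 2.0-fold higher number from compound 3 to compound 4 (0.30 log units; within the scatter), resting on that one measured step. Compound 4 is therefore expected to give about 600 mg/kg, between 250 mg/kg and 1500 mg/kg.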

Compound 4, minimum effective dose: 300 mg/kg
The estimate for compound 4 lay 2.0-fold (0.30 log units) above the measured number, within the range that was stated.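

In this assay, putting acetyl in place of methoxy on the core with the benzoyl-bearing acid part of compound 3 brought no change at the digits printed from compound 3 to compound 4 (within the scatter), so the step seen on the core of compound 1 did not reappear here. Set side by side, the two results show that this change does not have one fixed size in this series, and that a step measured on one core cannot simply be added to a value on another: the same change on two cores in this assay, a 3.0-fold higher number (0.48 log units; beyond the scatter) from compound 1 to compound 2 and no change at the digits printed (within the scatter) from compound 3 to compound 4, 3.0-fold (0.48 log units) apart, beyond the scatter of two such steps

This rests on just two pairs of compounds, so it does not show why the steps differ, or which feature of the acid part on the amide goes with the difference, and it gives no rule for how the change would behave on any further core.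

From the compounds shown here alone, it remains open whether the step would return on a core whose acid part has a longer chain or ends in a carboxylic acid, which would show whether the first step or the second is the more usual one. Also open, going by these compounds, is how an amine or a chlorine at the same place on the core would compare with methoxy and acetyl on each of the two cores.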